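Adding a Second Fluoro: From Compound 2 to Compound 4

A few compounds are considered here, and "the series" means these few. Any claim that something is new, unique, unknown or untested is made for them only; others in the source may bear on it.

Measured so far in an in vitro assay on BTI-TN-5B1-4 cells for inhibition of Amine oxidase [flavin-containing] A (Homo sapiens), read by Amplex Red, with a stated time of 15 min, tested at 100 uM; on this read-out higher numbers stand for more inhibition at the one concentration tested (going by the name of the read-out) and lower numbers for less inhibition:
compound 1, `C/C(=N/Nc1nc(-c2ccc(F)cc2)cs1)c1cccnc1`, gives 40%
compound 2, `Fc1ccc(-c2csc(N/N=C\c3cccc4ccccc34)n2)cc1`, gives 40%
compound 3, `C/C(=N/Nc1nc(-c2ccc(F)cc2F)cs1)c1cccnc1`, gives 40%

Compounds 1 and 3 differ in one place, (fluoro in place of hydrogen on an aromatic carbon), and that change made no change at the digits printed from compound 1 to compound 3 (within the scatter). How the core of compound 2 differs from the core of compound 1 is not broken down here; compound 2 stands level with compounds 1 and 3 in this assay. Compound 4, `Fc1ccc(-c2csc(N/N=C\c3cccc4ccccc34)n2)c(F)c1`, is not yet measured. It differs from compound 2 by fluoro in place of hydrogen on an aromatic carbon, the same change that was made from compound 1 to compound 3. Because that earlier change gave no change at the digits printed from compound 1 to compound 3 (within the scatter), the step from compound 2 to compound 4 in this assay is expected to be no change at the digits printed from compound 2 to compound 4 (within the scatter). Compound 4 is therefore estimated at 40%, in the range 28% to 52%, resting on a single precedent.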

Compound 4, a percentage reported as inhibition, at one concentration (the size of the read-out at that concentration, not a potency): 40%
Estimate against measurement, compound 4: no gap at the digits printed; measured number inside the range.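

In this assay, going from 4-fluorophenyl to 2,4-difluorophenyl gave no change at the digits printed from compound 2 to compound 4 (within the scatter). Set beside the earlier step, the same change gave the same outcome on both cores: the same change on two cores in this assay, no change at the digits printed (within the scatter) from compound 1 to compound 3 and no change at the digits printed (within the scatter) from compound 2 to compound 4, 0 percentage points apart, within the scatter of two such steps

This agreement holds for these two cores only; it does not show that the change would behave alike on any other core, and a reading at one concentration is not a potency. The compounds shown leave open whether a chloro, a methoxy or an amine in place of the added fluoro would read apart from these compounds. They also leave open whether a carboxylic acid on that ring would do so.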